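A few compounds are considered here, and "the series" means these few. Any claim that something is new, unique, unknown or untested is made for them only; others in the source may bear on it.

Compound 3 `OC[C@H]1O[C@@H](n2cnc3c(NCc4ccc(Cl)cc4Cl)ncnc32)[C@H](O)[C@@H]1O` gives 96300 nM in a functional assay on HL-60 cells (Homo sapiens) for antiproliferative activity, with a stated time of 72 h (on this read-out higher numbers stand for weaker inhibition and lower numbers for stronger inhibition), the higher of the two numbers reported; the other belongs to compound 1 `OC[C@H]1O[C@@H](n2cnc3c(NCc4ccccc4Br)ncnc32)[C@H](O)[C@@H]1O`, which gives 6600 nM in this assay. Compound 2 `Cc1ccc(CNc2ncnc3c2ncn3[C@@H]2O[C@H](CO)[C@@H](O)[C@H]2O)cc1` is reported in this assay only as a limit, > 166000 nM (the limit of > 166000 nM in this assay, at which 1 of the 3 values shown sits). Exchanging 2-bromophenyl for 2,4-dichlorophenyl brought a 15-fold higher number from compound 1 to compound 3 (1.16 log units; beyond the scatter), and exchanging it for 4-methylphenyl brought an at least 25-fold higher number from compound 1 to compound 2 (1.40 log units; beyond the scatter), while the step between the two weaker compounds is an at least 1.7-fold lower number from compound 2 to compound 3 (0.23 log units; that floor lies within the scatter). Compound 4 `COc1cccc(CNc2ncnc3c2ncn3[C@@H]2O[C@H](CO)[C@@H](O)[C@H]2O)c1O` differs from compound 3 in a single place: 2-hydroxy-3-methoxyphenyl in place of 2,4-dichlorophenyl on a saturated chain carbon bound to a nitrogen on an aromatic ring. Among the measured compounds shown here, no measured step carries a 2-hydroxy-3-methoxyphenyl, so the three steps bear only indirectly: each departure from 2-bromophenyl raised the number sharply, and the two groups that were not 2-bromophenyl ended close together near the top of the range. The chemist therefore expects compound 4 to remain in that upper region rather than recover the number of compound 1. The step estimated is a 1.0-fold higher number from compound 3 to compound 4 (0.02 log units; within the scatter), a change not beyond the scatter. The estimate for compound 4 in this assay is 100000 nM, ranging from 20000 nM to 250000 nM, with a real chance that only a limit is returned.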

Compound 4, half-maximal inhibitory concentration: 150 nM
Compound 4: the middle estimate sits 670-fold (2.82 log units) above what was measured, and the stated range ends above it.
By their numbers in this assay, from the lowest: compound 4; then compound 1; then compound 3. At a limit, above all of these: compound 2.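

In this assay, the 2-hydroxy-3-methoxyphenyl group on a saturated chain carbon bound to a nitrogen on an aromatic ring reverses the earlier picture, with a 640-fold lower number from compound 3 to compound 4 (2.81 log units; beyond the scatter) and a 44-fold lower number from compound 1 to compound 4 (1.64 log units; beyond the scatter). Until now, every change away from 2-bromophenyl at this place had only raised the number, whereas this change shows that the place can also go well below compound 1, and that the exchange of one substituted phenyl for another can move the number across most of the range seen here. The change from 4-methylphenyl reads an at least 1100-fold lower number from compound 2 to compound 4 (3.04 log units; beyond the scatter), which is a floor and not a size, since compound 2 is recorded only as a limit: the limit of > 166000 nM in this assay, at which 1 of the 4 values shown sits.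

The compounds shown leave open whether the hydroxyl or the methoxy accounts for the fall, as no phenyl here carries only one of the two. They also leave open whether the hydroxyl can be exchanged for an amine, or the methoxy for an ethoxy, without losing the low number of compound 4.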